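Series notes: piperidin-4-yl replaced by methyl on the aromatic nitrogen

This account rests on a few compounds, and the source may have more. Where it says the series, first, only, none or still open, it means among the compounds named here.

Measured compounds in a functional assay on MDA-MB-231 cells (Homo sapiens) for antiproliferative activity, read by MTT assay, with a stated time of 72 h; a lower number here means a stronger inhibitor, a higher number a weaker inhibitor:
compound 1 `CC(Nc1ncnc2ccc(-c3cnn(C4CCNCC4)c3)cc12)c1c(Cl)ccc(F)c1Cl` gives 12600 nM
compound 2 `c1cnc2ccc(Nc3ncnc4ccc(-c5cnn(C6CCNCC6)c5)cc34)cc2c1` gives 30300 nM
compound 3 `COc1cccc(CNc2ncnc3ncc(-c4cnn(C)c4)cc23)c1` gives only > 100000 nM, which is a limit of the assay, not a number

Among the measured compounds shown here, compound 2 has the highest of the two numbers in this assay; its nearest neighbour is compound 1, reached by the only measured step, a 2.4-fold higher number from compound 1 to compound 2 (0.38 log units; beyond the scatter). For the measured compounds named here, compound 3 sits at the limit of > 100000 nM in this assay, at which 1 of the 3 values shown sits, and differs from the others in more than one place, so no step to it can be counted.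

Compound 4 `Cn1cc(-c2ccc3ncnc(Nc4ccc5ncccc5c4)c3c2)cn1` is not yet measured. It differs from compound 2 in one place: methyl in place of piperidin-4-yl on an aromatic nitrogen. Going by the values given here, none of the measured steps touches this position; the one counted step, from compound 1 to compound 2, concerns the substituent on the other nitrogen and gives no direct guide. Among the compounds with values here, compound 3, the only compound carrying methyl at this nitrogen, shows a limit rather than a number, but other parts of its structure differ as well. The expectation for compound 4 is therefore uncertain and leans toward a higher number, a 2.0-fold higher number from compound 2 to compound 4 (0.30 log units; within the scatter), with a real chance of a limit. Compound 4 is estimated at 60000 nM in this assay, within 20000 nM to 200000 nM.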

Compound 4, half-maximal inhibitory concentration: 26300 nM
Compound 4: the middle estimate sits 2.3-fold (0.36 log units) above what was measured; measured number inside the range.
By their numbers in this assay, from the lowest: compound 1; then compounds 4 and 2 (each within the scatter of the next). At a limit, above all of these: compound 3.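

In this assay, the position on the aromatic nitrogen of the five-membered ring takes either piperidin-4-yl or methyl with values that cannot be told apart: a 1.2-fold lower number from compound 2 to compound 4 (0.06 log units; within the scatter). On this quinolin-6-yl series, the whole six-membered non-aromatic ring, with its hydrogen-bond donor and acceptor, can therefore leave without a step beyond the scatter. Methyl on this nitrogen does not by itself bring a compound to a limit, while compound 3, which carries methyl there and differs elsewhere as well, stands at a limit: the limit of > 100000 nM in this assay, at which 1 of the 4 values shown sits.

As far as these compounds go, whether the same exchange reads alike with the 1-(2,6-dichloro-3-fluorophenyl)ethyl group of compound 1 on the other nitrogen stays open. With only piperidin-4-yl and methyl at this position, the compounds shown also leave open how a longer chain ending in an amine or a carboxylic acid would read.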